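Acetyl in place of pyrimidin-2-yl: compound 4

The compounds below may be only part of what the source reports. "The series", "measured", "known", "first", "only" and "open" are said of these compounds alone.

Three measured compounds share one core and differ only at a single aromatic carbon. Compound 1 `NC(=O)c1cccc(-c2cnc(C(=O)CCCCCCc3ccccc3)o2)c1` gives 6 nM in an assay (Rattus norvegicus) for inhibition of Fatty-acid amide hydrolase 1 (Homo sapiens); on this read-out higher numbers stand for weaker inhibition and lower numbers for stronger inhibition; compound 2 `NC(=O)c1cccc(-c2cnc(C(=O)CCCCCCc3ccccc3)o2)n1` gives 1 nM; compound 3 `O=C(CCCCCCc1ccccc1)c1ncc(-c2ncccn2)o1` gives 5.3 nM. Compound 3 stands second highest of the three numbers; its gap to compound 1 lies within the scatter, while the step of a 5.3-fold higher number from compound 2 to compound 3 (0.72 log units; beyond the scatter) lies beyond it. Compound 4 `CC(=O)c1cnc(C(=O)CCCCCCc2ccccc2)o1` carries the change (acetyl in place of pyrimidin-2-yl on an aromatic carbon). The measured steps of a 1.1-fold lower number from compound 1 to compound 3 (0.05 log units; within the scatter) and a 6.0-fold lower number from compound 1 to compound 2 (0.78 log units; beyond the scatter) exchange one six-membered aromatic ring for another; none removes the ring altogether, so they bear only loosely on this step. The expected step is a 5.7-fold higher number from compound 3 to compound 4 (0.75 log units; beyond the scatter), toward a weaker number. Compound 4 is expected to give 30 nM, within a range of 5 nM to 200 nM.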

Compound 4, inhibition constant: 2 nM
The estimate for compound 4 lay 15-fold (1.18 log units) above the measured number; the measured number lies below the stated range.
By their numbers in this assay, from the lowest: compounds 2 and 4 (each within the scatter of the next); then compounds 3 and 1 (each within the scatter of the next).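

At this position of the shared core, a six-membered aromatic ring is not required for a low number in this assay: acetyl, with no ring, gives a 2.7-fold lower number from compound 3 to compound 4 (0.42 log units; beyond the scatter) and also a 3.0-fold lower number from compound 1 to compound 4 (0.48 log units; beyond the scatter) on the same read-out. The remaining step, a 2.0-fold higher number from compound 2 to compound 4 (0.30 log units; within the scatter), stays within the scatter, so acetyl and 6-carbamoylpyridin-2-yl cannot be told apart here. No measured evidence on the cause of these steps is at hand.

Open, on these data alone, is whether the carbonyl of acetyl or the absence of a ring matters more. A methyl ester, a carboxylic acid or a nitrile on this aromatic carbon would help separate the two.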